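Iodo for methyl on the aryl urea of compound 3

The source may hold more compounds than are shown below. What is called first, only, known or untested is meant among the compounds shown, and "the series" means these compounds.

The series shares the core of compound 1 `O=C(NCC1(c2ccccc2)CCCCC1)Nc1ccccc1`, which in an assay on microsomes from intestine for inhibition of acyl-CoA:cholesterol acyltransferase (Oryctolagus cuniculus) (on this read-out higher numbers stand for weaker inhibition and lower numbers for stronger inhibition), gives 2300 nM. Compound 2 `COc1ccccc1NC(=O)NCC1(c2ccccc2)CCCCC1` carries a methoxy on an aromatic carbon and gives 270 nM. Compound 3 `Cc1ccc(NC(=O)NCC2(c3ccccc3)CCCCC2)cc1` carries a methyl on an aromatic carbon and gives 4500 nM. Among the three numbers compound 3 stands highest; compound 1 is nearest to it and compound 2 furthest. The measured steps are a 2.0-fold higher number from compound 1 to compound 3 (0.29 log units; within the scatter), an 8.5-fold lower number from compound 1 to compound 2 (0.93 log units; beyond the scatter) and a 17-fold higher number from compound 2 to compound 3 (1.22 log units; beyond the scatter).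

Compound 4 `O=C(NCC1(c2ccccc2)CCCCC1)Nc1ccc(I)cc1` is still to be measured in this assay. Relative to compound 3 the change is iodo in place of methyl on an aromatic carbon, sitting on an aromatic carbon of a six-membered aromatic ring of carbon only, para to a large group. Within the data shown here, no measured step introduces a halogen anywhere, so nothing speaks directly to iodo. Among the measured compounds shown here, the only step at this place, methyl in place of hydrogen, was a 2.0-fold higher number from compound 1 to compound 3 (0.29 log units; within the scatter), within the scatter; the one step beyond the scatter, an 8.5-fold lower number from compound 1 to compound 2 (0.93 log units; beyond the scatter), concerns a different group at a different place and does not bear on compound 4. Hence no step beyond the scatter is expected in this assay, and compound 4 is estimated at 3000 nM, within 700 nM to 12000 nM, that is an expected step of a 1.5-fold lower number from compound 3 to compound 4 (0.18 log units; within the scatter).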

Compound 4, half-maximal inhibitory concentration: 2300 nM
Beside the measured number, compound 4's estimate is 1.3-fold (0.12 log units) above it; measured number inside the range.
By their numbers in this assay, from the lowest: compound 2; then compounds 1, 4 and 3 (each within the scatter of the next).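

In this assay, among these compounds, iodo is the first halogen, and with no change at the digits printed from compound 1 to compound 4 (within the scatter) and a 2.0-fold lower number from compound 3 to compound 4 (0.29 log units; within the scatter), hydrogen, methyl and iodo on this aromatic carbon, para to a large group, all lie within the scatter of one another, so none of the three changes at this place can be read as a real shift. Among the compounds shown here, with an 8.5-fold higher number from compound 2 to compound 4 (0.93 log units; beyond the scatter) added, the 2-methoxyphenyl of compound 2 stands apart from the 4-iodophenyl as well as from the phenyl and 4-methylphenyl groups, and it remains the only aryl group whose steps to all others lie beyond the scatter. Nothing among the data given accounts for the flat response at this place or for the separate standing of compound 2.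

Open, from the compounds shown here alone, is whether this place stays as flat with a group of a different kind, such as an amine or a carboxylic acid, in place of iodo. Also open, going by these compounds, is whether the gain seen with 2-methoxyphenyl belongs to the methoxy itself, which 4-methoxyphenyl and 2-iodophenyl would separate.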